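Aryl substituent change in the hydrazone series: compound 4

This account rests on a few compounds, and the source may have more. Where it says the series, first, only, none or still open, it means among the compounds named here.

Measured so far in a functional assay on the whole organism for inhibition, with Rattus norvegicus as the target; a higher number here means that more compound is needed for the effect, a lower number that less compound is needed:
Compound 1 `CC1CC/C(=N\Nc2cccc(Cl)c2)c2ncc(C(=O)O)c(=O)n21` gives > 100 umol/kg, a limit of the assay.
Compound 2 `CC1CC/C(=N\Nc2cccc(I)c2)c2ncc(C(=O)O)c(=O)n21` gives 1000 umol/kg.
Compound 3 `CCOc1ccc(N/N=C2\CCC(C)n3c2ncc(C(=O)O)c3=O)cc1` gives > 100 umol/kg, again a limit.

Compound 3 thus stands at the limit of > 100 umol/kg in this assay, at which 2 of the 3 values shown sit. Because of that limit, compound 3 cannot be placed against compound 1. Compound 4 `Cc1ccc(N/N=C2\CCC(C)n3c2ncc(C(=O)O)c3=O)cc1` differs from compound 3 by methyl in place of ethoxy on an aromatic carbon. For the measured compounds named here, the only measured step, a step that the limit leaves unreadable from compound 1 to compound 2, also changes a group on an aromatic carbon, but it is unreadable and concerns neither ethoxy nor methyl, so no measured step sets a size for the change to compound 4. The step that the limit leaves unreadable from compound 3 to compound 4 is therefore expected to be none beyond the scatter. Compound 4 is estimated at 300 umol/kg, with a range from 100 umol/kg to 1000 umol/kg.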

Compound 4, dose for 50% inhibition: > 1000 umol/kg
Compound 4 ended at the assay's limit (the forecaster's own chance of this, stated with the estimate: 65%); at least 3.3-fold (0.52 log units) between middle value and limit.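

With methyl para to a large group, compound 4 in this assay gives > 1000 umol/kg as a limit of the assay and not a number: the limit of > 1000 umol/kg in this assay, at which 1 of the 4 values shown sits.
The exchange of 3-iodophenyl for 4-methylphenyl gives a number no lower from compound 2 to compound 4 (the limit leaves the size open), so this exchange shows no drop in the dose needed.
The steps to compound 4 from compound 1 and from compound 3 cannot be read, because limits stand in the way: the limit of > 100 umol/kg in this assay, at which 2 of the 4 values shown sit.

On these data alone, whether methyl and ethoxy differ at all at this position stays open.
So does how an amine or a carboxylic acid in that place would read in this assay.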